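Returning from a Sulfonamide to a Sulfonyl Chain

The compounds below may be only part of what the source reports. "The series", "measured", "known", "first", "only" and "open" are said of these compounds alone.

Of the compounds shown here, three on one shared core have been tested in a functional assay on the whole organism (strain ICR) for inhibition, with Mus musculus as the target, with a stated time of 16 h, at a dose of 10 mg/kg by the oral route; a higher number here means more inhibition at the dose given (going by the name of the read-out), a lower number less inhibition. Compound 1 `CCSCCC12CCC(c3nnc(-c4ccccc4C(F)(F)F)n3C)(CC1)CC2` gives 72%. Compound 2 `Cn1c(-c2ccccc2C(F)(F)F)nnc1C12CCC(CCS(C)(=O)=O)(CC1)CC2` gives 63%, and a number 9 percentage points lower from compound 1 to compound 2 (within the scatter). Compound 3 `Cn1c(-c2ccccc2C(F)(F)F)nnc1C12CCC(CNS(C)(=O)=O)(CC1)CC2` gives 27%, the lowest of the three numbers, with a number 45 percentage points lower from compound 1 to compound 3 (beyond the scatter) and a number 36 percentage points lower from compound 2 to compound 3 (beyond the scatter). Compound 4 `CC(C)S(=O)(=O)CCC12CCC(c3nnc(-c4ccccc4C(F)(F)F)n3C)(CC1)CC2` is not yet measured and differs from compound 3 in one place: (isopropylsulfonyl)methyl in place of methanesulfonamido on a saturated chain carbon bound to a saturated ring carbon. This change removes the methanesulfonamido group and puts back a sulfonyl-bearing chain of the kind seen in compound 2, so the step of a number 36 percentage points lower from compound 2 to compound 3 (beyond the scatter) bears most directly on it, with a number 45 percentage points lower from compound 1 to compound 3 (beyond the scatter) pointing the same way. A rise of about a number 38 percentage points higher from compound 3 to compound 4 (beyond the scatter) is therefore expected. Compound 4 is estimated at 65%, with a range from 45% to 85%.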

Compound 4, a percentage reported as inhibition, in the whole organism at one dose (the size of the read-out at that dose, not a potency): 59%
Beside the measured number, compound 4's estimate is 6 percentage points above it; the measured number falls inside the stated range.
By their numbers in this assay, from the lowest: compound 3; then compounds 4, 2 and 1 (each within the scatter of the next, the first and the last beyond it).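

In this assay the isopropylsulfonyl chain brings the number back up, a number 32 percentage points higher from compound 3 to compound 4 (beyond the scatter), so the low value of compound 3 does not hold for every sulfonyl-bearing chain at this position. The sulfonyl sulfur also accepts a larger group, since isopropyl in place of methyl gives a number 4 percentage points lower from compound 2 to compound 4 (within the scatter). The thioether keeps a modest edge over this sulfone, a number 13 percentage points lower from compound 1 to compound 4 (beyond the scatter).

Whether a carboxylic acid or a longer chain in place of the sulfonyl group would keep this inhibition remains open, and no measurement here explains any of these steps.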